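The source may report more compounds than this note shows. Statements on the series, on what has been measured and on what is new or still open speak of the compounds shown alone.

Measured compounds:
compound 1 `COc1cc(-c2nnc3n2NC(c2ccco2)C(C(=O)c2ccc(F)c(F)c2)S3)cc(OC)c1OC`, 36000 nM
compound 2 `COc1ccc(C(=O)C2Sc3nnc(-c4cc(OC)c(OC)c(OC)c4)n3NC2c2ccco2)cc1`, > 100000 nM
compound 3 `COc1cc(-c2nnc3n2NC(c2ccco2)C(C(=O)c2cccc(Br)c2)S3)cc(OC)c1OC`, 63900 nM

In a functional assay on PC-3 cells (Homo sapiens) for cytotoxicity, read by MTT assay, with a stated time of 48 h (on this read-out lower numbers stand for stronger inhibition and higher numbers for weaker inhibition), compound 3 gives the highest of the two numbers; compound 1 sits nearest to it, a 1.8-fold higher number from compound 1 to compound 3 (0.25 log units; within the scatter). Compound 2 gives only a limit of this assay, (the limit of > 100000 nM in this assay, at which 1 of the 3 values shown sits). Compound 4 `COc1cc(-c2nnc3n2NC(c2ccco2)C(C(=O)c2cccs2)S3)cc(OC)c1OC` differs from compound 3 by thiophen-2-yl in place of 3-bromophenyl on a carbonyl carbon. The measured steps all swap the aryl group on the carbonyl carbon: an at least 2.7-fold higher number from compound 1 to compound 2 (0.44 log units; beyond the scatter), a 1.8-fold higher number from compound 1 to compound 3 (0.25 log units; within the scatter) and an at least 1.5-fold lower number from compound 2 to compound 3 (0.19 log units; that floor lies within the scatter). None of them involves thiophen-2-yl, and the two numbered steps are small, so compound 4 is expected to stay close to compound 3, a 1.3-fold lower number from compound 3 to compound 4 (0.11 log units; within the scatter). The estimate for compound 4 is 50000 nM, with a range from 20000 nM to 120000 nM.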

Compound 4, half-maximal inhibitory concentration: 46200 nM
Compound 4: middle estimate off by 1.1-fold (0.03 log units), on the high side; measured number inside the range.
By their numbers in this assay, from the lowest: compounds 1, 4 and 3 (each within the scatter of the next). At a limit, above all of these: compound 2.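

In this assay, thiophen-2-yl shows that the carbonyl carbon carries a five-membered sulfur-containing aromatic ring with no change beyond the scatter from the 3-bromophenyl or 3,4-difluorophenyl groups: a 1.4-fold lower number from compound 3 to compound 4 (0.14 log units; within the scatter), and a 1.3-fold higher number from compound 1 to compound 4 (0.11 log units; within the scatter). Set against 4-methoxyphenyl, the same ring gives an at least 2.1-fold lower number from compound 2 to compound 4 (0.33 log units; beyond the scatter). That step is only a floor, as compound 2 is a limit: the limit of > 100000 nM in this assay, at which 1 of the 4 values shown sits.

What the compounds shown leave open is how a non-aromatic group at this carbonyl carbon, such as a piperidine, or an aryl ring bearing an amine or a carboxylic acid, would read out.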